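Compound 3 to compound 4: ethoxycarbonyl replaced by hydroxymethyl

The source may hold more compounds than are shown below. What is called first, only, known or untested is meant among the compounds shown, and "the series" means these compounds.

Three members of the series have numbers in a functional assay on the whole organism for inhibition, with Rattus norvegicus as the target, read by paw edema, with stated times of 1 h and 3 h; a higher number here means that more compound is needed for the effect, a lower number that less compound is needed. Compound 1 (`C/C(=N\OCCCC(=O)O)c1ccc(Cl)cc1`) gives 58 mg/kg, compound 2 (`C/C(=N\OC(C)C(=O)O)c1ccc(Cl)cc1`) gives 55 mg/kg and compound 3 (`CCOC(=O)CO/N=C(\C)c1ccc(Cl)cc1`) gives 32 mg/kg. Compound 3 thus stands within the scatter of both other compounds, and the three values are not separated from one another.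

The change under review leads to compound 4 (`C/C(=N\OCCO)c1ccc(Cl)cc1`), with hydroxymethyl in place of ethoxycarbonyl on a saturated chain carbon bound to an oxygen on an unsaturated carbon.

Among the measured compounds shown here, one measured step bears directly on this part of the molecule: a 1.8-fold lower number from compound 1 to compound 3 (0.26 log units; within the scatter). That step brought ethoxycarbonyl in place of 2-carboxyethyl and stays within the scatter. For the measured compounds named here, no measured compound carries hydroxymethyl, so the evidence for this replacement is indirect and the range has to stay wide. Given the size of the step of a 1.8-fold lower number from compound 1 to compound 3 (0.26 log units; within the scatter), no change beyond the scatter is expected here. The expected step is a 1.4-fold higher number from compound 3 to compound 4 (0.15 log units; within the scatter), which is no clear shift in either direction. For compound 4 the estimate is 45 mg/kg, with an expected range from 20 mg/kg to 100 mg/kg.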

Compound 4, dose for half-maximal effect: 29 mg/kg
For compound 4 the middle estimate is 1.6-fold (0.19 log units) above the measured one; measured number inside the range.
By their numbers in this assay, from the lowest: compounds 4, 3, 2 and 1 (each within the scatter of the next).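

In this assay, hydroxymethyl stands in place of ethoxycarbonyl on a saturated chain carbon bound to an oxygen on an unsaturated carbon with a 1.1-fold lower number from compound 3 to compound 4 (0.04 log units; within the scatter) as the step, so an end group with fewer heavy atoms, a hydrogen-bond donor and no ester leaves the number within the scatter. Set against the two carboxylic acids, the 2-hydroxyethyl chain of compound 4 also stays within the scatter, with a 1.9-fold lower number from compound 2 to compound 4 (0.28 log units; within the scatter) as one step and a 2.0-fold lower number from compound 1 to compound 4 (0.30 log units; within the scatter) as the other, so ester, acid and alcohol ends on this chain are not separated in this assay. No measurement in hand offers an explanation for these close readings.

From the compounds shown here alone, all four compounds keep the same core and an oxygen at the end of the chain, so it remains open whether an amine or a primary amide in that place, or a longer chain ending in hydroxy, would read differently. With every step among these compounds within the scatter, the series does not yet show which kind of change at this position could move the number beyond it.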